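A few compounds are considered here, and "the series" means these few. Any claim that something is new, unique, unknown or untested is made for them only; others in the source may bear on it.

Measured so far in an assay for inhibition of high affinity nerve growth factor receptor (Homo sapiens), read by HTRF, with a stated time of 30 min, in the presence of a further agent that is not named here; on this read-out lower numbers stand for stronger inhibition and higher numbers for weaker inhibition:

compound 1, `Cc1cc(Nc2nc(NCc3ccc(F)cc3F)nc3ccc(F)cc23)n[nH]1`, gives 44 nM
compound 2, `Cc1cc(Nc2nc(NCc3ccc(F)cc3F)nc3ccc(Cl)cc23)n[nH]1`, gives 520 nM
compound 3, `Cc1cc(Nc2nc(NCc3ccc(F)cc3F)nc3cc(F)ccc23)n[nH]1`, gives 62 nM

Compound 2 is compound 1 with chloro in place of fluoro on an aromatic carbon. Within the data shown here, that single change moves the read-out in this assay by a 12-fold higher number from compound 1 to compound 2 (1.07 log units; beyond the scatter), the one large step seen among the measured compounds.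

Compound 3 has the same atoms as compound 1, joined differently; the difference between the two cores is not broken down here. In this assay compound 3 gives 62 nM, and that number and the number for compound 1 lie within the usual scatter of each other, so no ordering of the two is claimed.

Compound 4, `Cc1cc(Nc2nc(NCc3ccc(F)cc3F)nc3cc(Cl)ccc23)n[nH]1`, has not yet been measured. It stands to compound 3 as compound 2 stands to compound 1: the change is chloro in place of fluoro on an aromatic carbon, and the description of its surroundings matches that of the earlier change word for word, so it is taken as the same change on the other core.

The expectation for compound 4 rests on one measured instance only. Because the earlier change gave a 12-fold higher number from compound 1 to compound 2 (1.07 log units; beyond the scatter), the step from compound 3 to compound 4 is expected to be an 11-fold higher number from compound 3 to compound 4 (1.05 log units; beyond the scatter). Whether the core of compound 3 answers the change in the same way is not shown by any other pair here, which widens the range. Compound 4 is therefore estimated at 700 nM in this assay, with a likely range from 250 nM to 2000 nM.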

Compound 4, half-maximal inhibitory concentration: 15 nM
Compound 4: middle estimate off by 47-fold (1.67 log units), on the high side; the whole stated range lies above it.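

In this assay, chloro in place of fluoro on an aromatic carbon now gives a 4.1-fold lower number from compound 3 to compound 4 (0.62 log units; beyond the scatter), so the two measured instances of this change run in opposite directions: the same change on two cores in this assay, a 12-fold higher number (1.07 log units; beyond the scatter) from compound 1 to compound 2 and a 4.1-fold lower number (0.62 log units; beyond the scatter) from compound 3 to compound 4, 49-fold (1.69 log units) apart, beyond the scatter of two such steps This shows that, within the compounds at hand, the step measured on the core of compound 1 does not transfer to the core of compound 3 in either size or direction, so the effect of this change has to be read separately on each core. Among these compounds, it does not show why the two cores answer differently, and with only one pair per core it cannot establish that either direction is general for its core.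

The compounds shown leave open how a hydrogen, a methyl, a methoxy or a nitrile on the same aromatic carbon would read on each core, and so whether the opposite behaviour is particular to the swap between fluoro and chloro. They also leave open whether the difference between the cores persists when the methyl group shared by all four compounds gives way to an ethyl or a carboxylic acid.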